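Removing one methoxy from a dimethoxy benzylidene ketone

The compounds below may be only part of what the source reports. "The series", "measured", "known", "first", "only" and "open" are said of these compounds alone.

Compound 1 (`COc1ccc(/C=C2\CCC/C(=C\c3ccc([N+](=O)[O-])cc3)C2=O)cc1OC`) carries two methoxy groups on one of its aromatic rings. In a functional assay on HSC-3 cells (Homo sapiens) for cytotoxicity (on this read-out higher numbers stand for lower toxicity in this test and lower numbers for higher toxicity in this test), compound 1 gives 4400 nM and stands at the lowest of the two plain numbers recorded. Compound 3 (`COc1cc(/C=C2\CCC/C(=C\c3ccc([N+](=O)[O-])cc3)C2=O)cc(OC)c1OC`), which adds a third methoxy, gives 4700 nM in this assay; the step of a 1.1-fold higher number from compound 1 to compound 3 (0.03 log units; within the scatter) shows that adding a methoxy here left the toxicity unchanged within the scatter. Compound 2 (`COc1ccc(/C=C2\CC/C(=C\c3ccc([N+](=O)[O-])cc3)C2=O)cc1`), built on a different core with a single methoxy, gives > 400000 nM in this assay, a limit of the measurement rather than a number. This is the limit of > 400000 nM in this assay, at which 1 of the 3 values shown sits.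

Compound 4 (`COc1ccc(/C=C2\CCC/C(=C\c3ccc([N+](=O)[O-])cc3)C2=O)cc1`) is compound 1 with one methoxy taken away: hydrogen in place of methoxy on an aromatic carbon. Among the compounds with values here, no measured step reports exactly this removal on the shared core of compound 1. Within the data shown here, the only step that touches methoxy count, from compound 1 to compound 3, was within the scatter, which suggests the methoxy pattern on this ring matters little. The result for compound 2 is a caution, but it cannot be tied to the methoxy alone. Compound 4 is therefore expected to give 6500 nM in this assay, within 2000 nM to 40000 nM, a step of a 1.5-fold higher number from compound 1 to compound 4 (0.17 log units; within the scatter) that is expected to stay modest.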

Compound 4, half-maximal cytotoxic concentration: > 400000 nM
Compound 4 ended at the assay's limit (the forecaster's own chance of this, stated with the estimate: 15%); at least 61-fold (1.78 log units) between middle value and limit.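

Hydrogen in place of the methoxy that sits ortho to a methoxy group and meta to a large group gives an at least 90-fold higher number from compound 1 to compound 4 (1.95 log units; beyond the scatter) in this assay, so on the shared core this one methoxy separates a measurable toxicity from none detected within the assay's range. The earlier step on this ring, a 1.1-fold higher number from compound 1 to compound 3 (0.03 log units; within the scatter), showed only that adding a further methoxy to compound 1 leaves the number within the scatter, and the new result shows that the ring is not indifferent to its methoxy groups: adding one and removing one have very different outcomes here. From the compounds shown here alone, compound 4 gives > 400000 nM, which is a limit of the assay and not a number, so the true size of the step remains unknown: the limit of > 400000 nM in this assay, at which 2 of the 4 values shown sit.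

The compounds shown leave open whether a methoxy is specifically needed on this carbon or whether another group, such as a hydroxyl, an amine or a longer ethoxy chain, would restore a measurable value. Within the data shown here, they also leave open whether the single methoxy of compound 4 would give the same result at a different place on the ring.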